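Ethoxy in Place of Dimethylamino: Expectation for Compound 4

The source may report more compounds than this note shows. Statements on the series, on what has been measured and on what is new or still open speak of the compounds shown alone.

Of the compounds shown here, three built on a shared core have been measured in an assay on HL-60 cells for inhibition of glutathione S-transferase P (Homo sapiens), read by spectrophotometry, tested at 20 uM; a lower number here means less inhibition, a higher number more inhibition at the concentration tested (going by the name of the read-out). Compound 1 `Cc1cccc(/C=C2\CN(CC(=O)O)c3c(C)cccc3C2=O)c1` gives 39.1%. Compound 2 `Cc1cccc2c1N(CC(=O)O)C/C(=C\c1ccc(N(C)C)cc1)C2=O` gives 13.2%, the second highest of the three numbers. Its nearest neighbour is compound 3 `COc1cc(/C=C2\CN(CC(=O)O)c3c(C)cccc3C2=O)cc(OC)c1OC`, which gives 0.85%, a number below that of compound 2 by a gap beyond the scatter. Compound 1 lies furthest from compound 2, above it by a gap that is also beyond the scatter.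

Compound 4 `CCOc1ccc(/C=C2\CN(CC(=O)O)c3c(C)cccc3C2=O)cc1` has not yet been measured in this assay. It differs from compound 2 in one place: ethoxy in place of dimethylamino on an aromatic carbon. No pair of measured compounds differs by this same change, so the numbers shown do not fix its size. Going by the values given here, what the values do show is that compound 3, the only measured compound carrying oxygen-linked groups on its aromatic ring, gives the lowest number, while compound 2 sits well above it. On that basis compound 4 is expected to give about 16% in this assay, with a range from 2% to 36%. The expected step of a number 2.8 percentage points higher from compound 2 to compound 4 (within the scatter) is small and not beyond the scatter in either direction.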

Compound 4, a percentage reported as inhibition, at one concentration (the size of the read-out at that concentration, not a potency): 42.4%
For compound 4 the middle estimate is 26.4 percentage points below the measured one; the measured number lies above the stated range.
By their numbers in this assay, from the lowest: compound 3; then compound 2; then compounds 1 and 4 (each within the scatter of the next).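

Going by these compounds alone, this is the first one-place step: in this assay, ethoxy in place of dimethylamino on an aromatic carbon, para to a large group, gives a number 29.2 percentage points higher from compound 2 to compound 4 (beyond the scatter) and so shows that the number responds to the group held at this position. The change leaves the counts unaltered, with three heavy atoms, no ring, no hydrogen-bond donors, one hydrogen-bond acceptor and no net charge on either side, so the step comes with nitrogen giving way to oxygen in a group of the same size by those counts. Nothing available accounts for the size or direction of this step.

The compounds shown leave open whether the step belongs to the oxygen link or to the ethyl chain, which methoxy, hydroxy or a longer chain such as propoxy at the same place would help to separate. They also leave open whether diethylamino or a primary amine would stay near compound 2 , and, with one tested concentration, how the step would translate into potency.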